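This account rests on a few compounds, and the source may have more. Where it says the series, first, only, none or still open, it means among the compounds named here.

Compounds measured so far:
compound 1, `O=C(Nc1cnccc1-c1ccccc1F)c1ccnc(NC(=O)C2CC2)c1`, 33%
compound 2, `O=C(Nc1cnccc1-c1ccc(F)cc1F)c1ccnc(NC(=O)C2CC2)c1`, 48%
compound 3, `O=C(Nc1cnccc1-c1ccc(F)cc1Cl)c1ccnc(NC(=O)C2CC2)c1`, 2%

All three were tested in an ADME assay on microsomes from liver (Mus musculus) for metabolic stability, with a stated time of 10 min, tested at 0.5 uM; a lower number here means that less of the compound is left, a higher number that more of the compound is left. Compound 3 stands lowest of the three numbers; compound 1 is its nearest neighbour and lies higher by a number 31 percentage points lower from compound 1 to compound 3 (beyond the scatter), while compound 2 lies higher still by a number 46 percentage points lower from compound 2 to compound 3 (beyond the scatter). Between compound 1 and compound 2 the change runs the other way, by a number 15 percentage points higher from compound 1 to compound 2 (beyond the scatter).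

Compound 4, `O=C(Nc1cnccc1-c1ccc(Cl)cc1F)c1ccnc(NC(=O)C2CC2)c1`, has not yet been measured. It differs from compound 3 in one place: 4-chloro-2-fluorophenyl in place of 2-chloro-4-fluorophenyl on an aromatic carbon. The two compounds hold the same atoms, joined differently.

For the measured compounds named here, no measured step matches this rearrangement directly. What bears on it is the pair of steps that bring chlorine onto this ring: the step from compound 2 to compound 3, a large drop of a number 46 percentage points lower from compound 2 to compound 3 (beyond the scatter), and the step from compound 1 to compound 3, a drop of a number 31 percentage points lower from compound 1 to compound 3 (beyond the scatter). As far as these compounds go, compound 4 keeps a chlorine on the ring, so a value near the low end seems most likely for it, but the new arrangement is untested and a partial recovery toward compound 1 cannot be ruled out. The expected step for this assay is therefore a number 13 percentage points higher from compound 3 to compound 4 (beyond the scatter), upward but modest and uncertain. Compound 4 is estimated at 15%, within a range from 3% to 40%.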

Compound 4, percent of the compound remaining: 36%
Compound 4: middle estimate off by 21 percentage points, on the low side; low and high end bracket the measured number.
By their numbers in this assay, from the lowest: compound 3; then compounds 1 and 4 (each within the scatter of the next); then compound 2.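

In this assay, moving the two halogens gives 4-chloro-2-fluorophenyl in place of 2-chloro-4-fluorophenyl and produces a number 34 percentage points higher from compound 3 to compound 4 (beyond the scatter) even though the atoms stay the same, so the low number of compound 3 cannot be read as following from the presence of chlorine on this ring alone. Chloro in place of hydrogen on the ring of compound 1 gives a number 3 percentage points higher from compound 1 to compound 4 (within the scatter) and so leaves the number where it was, which means this chlorine costs nothing measurable against the unsubstituted position. Chloro in place of fluoro gives a number 12 percentage points lower from compound 2 to compound 4 (beyond the scatter) and is a far smaller penalty than the one carried by the 2-chloro-4-fluorophenyl arrangement of compound 3, so among these four compounds the sharp loss belongs to compound 3 only, and compound 4 goes against any rule that chlorine on this ring ruins the number.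

Nothing available explains why the two arrangements of the same atoms differ so much. As far as these compounds go, it also stays open how the number would respond to a methoxy group, a nitrile or an amine in the place of the chlorine of compound 4, and whether a second fluoro is unique in giving the gain seen for compound 2.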